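A few compounds are considered here, and "the series" means these few. Any claim that something is new, unique, unknown or untested is made for them only; others in the source may bear on it.

Of the compounds shown here, three sharing one core have been measured so far, and compound 1 `C=C1C(=O)O[C@@H]2CC(C)=C([C@@H](C)CCCOC(C)=O)[C@@H](OC(=O)CCl)[C@H]12` stands at the weak end: in a functional assay on HeLa cells (Homo sapiens) for cytotoxicity, read by sulforhodamine B assay, with a stated time of 72 h (on this read-out lower numbers stand for stronger inhibition and higher numbers for weaker inhibition), compound 1 gives 28500 nM, the highest of the three numbers. Compound 2 `C=C1C(=O)O[C@@H]2CC(C)=C([C@@H](C)CCCOC(C)=O)[C@@H](OC(=O)CN3CCCC3)[C@H]12` gives 12700 nM, and compound 3 `C=C1C(=O)O[C@@H]2CC(C)=C([C@@H](C)CCCOC(C)=O)[C@@H](OC(=O)COc3cccc4[nH]nnc34)[C@H]12` gives 23000 nM. The step of a 2.2-fold lower number from compound 1 to compound 2 (0.35 log units; beyond the scatter) is the only one that clears the scatter; the step of a 1.2-fold lower number from compound 1 to compound 3 (0.09 log units; within the scatter) does not, and neither does the step of a 1.8-fold higher number from compound 2 to compound 3 (0.26 log units; within the scatter).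

Compound 4 `C=C1C(=O)O[C@@H]2CC(C)=C([C@@H](C)CCCOC(C)=O)[C@@H](OC(=O)c3ccc(F)cc3)[C@H]12` differs from compound 1 at the ester on the core: 4-fluorophenyl in place of chloromethyl on a carbonyl carbon. The two measured steps from compound 1 both replace the chlorine at that ester and bear on this change only loosely, since here the whole chloromethyl leaves and the new group sits directly on the carbonyl carbon. Both were small, so a step of modest size at most is expected, direction uncertain. Compound 4 is therefore estimated at 20000 nM (range 8000 nM to 50000 nM), which would mean an expected step of a 1.4-fold lower number from compound 1 to compound 4 (0.15 log units; within the scatter).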

Compound 4, half-maximal inhibitory concentration: 12000 nM
Estimate against measurement, compound 4: 1.7-fold (0.22 log units) above; the measured number falls inside the stated range.
By their numbers in this assay, from the lowest: compounds 4, 2, 3 and 1 (each within the scatter of the next, the first and the last beyond it).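

Setting 4-fluorophenyl directly on the carbonyl carbon, with the whole chloromethyl gone, gives a 2.4-fold lower number from compound 1 to compound 4 (0.38 log units; beyond the scatter), so this ester position accepts an aromatic ring without the chain carbon that compounds 1, 2 and 3 all keep. The change does not separate this ester from the other two, since a 1.1-fold lower number from compound 2 to compound 4 (0.02 log units; within the scatter) and a 1.9-fold lower number from compound 3 to compound 4 (0.28 log units; within the scatter) both stay within the scatter, even though 4-fluorophenyl and (pyrrolidin-1-yl)methyl are very different groups. Nothing at hand explains why these steps take the size they do.

As far as these compounds go, whether the fluorine plays any part stays open, and a plain phenyl or a 4-chlorophenyl on the same carbonyl carbon would test that. Also open, from the compounds shown here alone, is what a free hydroxyl in place of the whole ester would do.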